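Moving a Hydroxyl Group on a Pyridine Core

A few compounds are considered here, and "the series" means these few. Any claim that something is new, unique, unknown or untested is made for them only; others in the source may bear on it.

Compound 1 `Oc1ccc(-c2cc(-c3ccccn3)cc(-c3cccc(O)c3)n2)cc1` gives 1930 nM in a functional assay on HeLa cells (Homo sapiens) for cytotoxicity, read by CCK-8 assay; a lower number here means a stronger inhibitor, a higher number a weaker inhibitor. Compound 2 `Oc1ccc(-c2cc(-c3ccccn3)cc(-c3ccc(O)cc3)n2)cc1` differs from it by 4-hydroxyphenyl in place of 3-hydroxyphenyl on an aromatic carbon. In this assay compound 2 reaches only a limit, > 50000 nM. That change produced an at least 25-fold higher number from compound 1 to compound 2 (1.41 log units; beyond the scatter). Compound 3 `Oc1cccc(-c2cc(-c3cccnc3)cc(-c3cccc(O)c3)n2)c1` also reaches only a limit in this assay, > 50000 nM. The difference between the cores of compound 1 and compound 3 is not broken down here. Compound 4 `Oc1ccc(-c2cc(-c3cccnc3)cc(-c3cccc(O)c3)n2)cc1` is not yet measured and differs from compound 3 by 4-hydroxyphenyl in place of 3-hydroxyphenyl on an aromatic carbon. This is the same kind of change as before, though the surroundings differ: earlier the place was meta to a 4-hydroxyphenyl group and meta to a pyridin-2-yl group, here it is meta to a 3-hydroxyphenyl group and meta to a pyridin-3-yl group. Compound 3 already sits at the limit of > 50000 nM in this assay, at which 2 of the 3 values shown sit, and the earlier change gave an at least 25-fold higher number from compound 1 to compound 2 (1.41 log units; beyond the scatter). Compound 4 is therefore expected to stay near that limit, with an expected step that the limit leaves unreadable from compound 3 to compound 4. The estimated value for compound 4 is 60000 nM, between 8000 nM and 300000 nM.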

Compound 4, half-maximal inhibitory concentration: > 50000 nM
Compound 4: only a limit was reported (the forecaster's own chance of this, stated with the estimate: 70%); the middle value is on the limit's open side.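

In this assay compound 4 gives > 50000 nM, which is a limit of the assay and not a number. For the compounds shown here, compound 3 also stands only at a limit, so the step between them cannot be read, and the data neither show nor rule out that moving the hydroxyl has the same effect on this core as on the core of compound 1: the limit of > 50000 nM in this assay, at which 3 of the 4 values shown sit. The one readable step, with pyridin-3-yl in place of pyridin-2-yl, is an at least 25-fold higher number from compound 1 to compound 4 (1.41 log units; beyond the scatter).

Still open, as far as these compounds go, is whether an amine or a carboxylic acid in place of either hydroxyl would give a readable value on the core of compound 3. Also open, from the compounds shown here alone, is how a pyridin-4-yl group would compare with pyridin-2-yl.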